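Moving the chlorine on the outer ring of compound 2

The source may report more compounds than this note shows. Statements on the series, on what has been measured and on what is new or still open speak of the compounds shown alone.

Measured so far:
Compound 1 `C[C@@H](Nc1nccc(Cl)c1NC(=O)CC#N)c1ccc(-c2cccc(F)c2C(F)(F)F)cc1`, in an assay on CHO cells for displacement of a labelled ligand from B1 bradykinin receptor (Homo sapiens) (a lower number here means a stronger inhibitor, a higher number a weaker inhibitor), compound 1 gives 1.1 nM.
Compound 2 `COC(=O)c1c(Cl)cccc1-c1ccc([C@@H](C)Nc2nccc(Cl)c2NC(=O)CC#N)cc1`, in this assay compound 2 gives 0.7 nM.

Compound 2 has the lower of the two numbers, but the step between them is a 1.6-fold lower number from compound 1 to compound 2 (0.20 log units; within the scatter), so the two are not told apart. Compound 3 `COC(=O)c1ccc(Cl)cc1-c1ccc([C@@H](C)Nc2nccc(Cl)c2NC(=O)CC#N)cc1` keeps every atom of compound 2 and only shifts the chlorine: 5-chloro-2-(methoxycarbonyl)phenyl in place of 3-chloro-2-(methoxycarbonyl)phenyl on an aromatic carbon. Among the compounds with values here, no measured step tests this kind of shift; the one known step, a change of the whole outer ring, stayed within the scatter. For compound 3 the expected change is therefore small, a 1.4-fold higher number from compound 2 to compound 3 (0.15 log units; within the scatter), and compound 3 is estimated at 1 nM with a range of 0.3 nM to 3.5 nM.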

Compound 3, inhibition constant: 0.8 nM
Compound 3: middle estimate off by 1.3-fold (0.10 log units), on the high side; low and high end bracket the measured number.
By their numbers in this assay, from the lowest: compounds 2, 3 and 1 (each within the scatter of the next).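

In this assay the shift from 3-chloro-2-(methoxycarbonyl)phenyl to 5-chloro-2-(methoxycarbonyl)phenyl shows a 1.1-fold higher number from compound 2 to compound 3 (0.06 log units; within the scatter) and so cannot be told from no effect at all: for these two placements, where the chlorine sits makes no readable difference. Compound 3 also shows a 1.4-fold lower number from compound 1 to compound 3 (0.14 log units; within the scatter) and thus stands level with compound 1 as well. Nothing measured here explains why the chlorine shift leaves the number in place. Open, on these data alone, is whether an amine in place of the chlorine, or a carboxylic acid in place of the methyl ester, would carry the number beyond the scatter.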